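The source may report more compounds than this note shows. Statements on the series, on what has been measured and on what is new or still open speak of the compounds shown alone.

Compound 1 `N=C(N)N/N=C/c1ccc(/C=C/C(=O)c2cccc(Br)c2)cc1` — 49.7%
Compound 2 `N=C(N)N/N=C/c1ccc(/C=C/C(=O)c2cccc(Cl)c2)cc1` — 80.7%

Within the data shown here, in a functional assay on the whole organism (Ear) for inhibition, with Mus musculus as the target, with a stated time of 30 min, at a dose of 100 mg/kg by the intraperitoneal route (a lower number here means less inhibition, a higher number more inhibition at the dose given (going by the name of the read-out)), compound 2 gives the higher of the two numbers so far; compound 1 sits a number 31 percentage points higher from compound 1 to compound 2 (beyond the scatter) below it. Compound 3 `N=C(N)N/N=C/c1ccc(/C=C/C(=O)c2ccc(Cl)cc2)cc1` differs from compound 2 by 4-chlorophenyl in place of 3-chlorophenyl on a carbonyl carbon. Among the measured compounds shown here, the one measured step concerns a change of halogen, not the point at which the halogen is joined, so nothing measured bears directly on this step; its size is untested. Compound 3 is therefore expected to remain of a similar order, with a wide range: an estimate of 65%, between 35% and 90%, meaning an expected step of a number 15.7 percentage points lower from compound 2 to compound 3 (beyond the scatter).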

Compound 3, a percentage reported as inhibition, in the whole organism at one dose (the size of the read-out at that dose, not a potency): 56.4%
Compound 3: middle estimate off by 8.6 percentage points, on the high side; measured number inside the range.
By their numbers in this assay, from the lowest: compounds 1 and 3 (each within the scatter of the next); then compound 2.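

In this assay the aryl group on the carbonyl carbon responds to where the chlorine sits, not only to which halogen is present: 4-chlorophenyl in place of 3-chlorophenyl gives a clear step (a number 24.3 percentage points lower from compound 2 to compound 3 (beyond the scatter)). 4-chlorophenyl in place of 3-bromophenyl, by contrast, gives a step that does not separate the two (a number 6.7 percentage points higher from compound 1 to compound 3 (within the scatter)). Nothing available accounts for either step.

Still open, on these data alone, is how 4-bromophenyl would compare with 4-chlorophenyl. Also open, as far as these compounds go, is how a methoxy group or an amine would compare with the halogens on this ring.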